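This account rests on a few compounds, and the source may have more. Where it says the series, first, only, none or still open, it means among the compounds named here.

Measured compounds in a functional assay on U-937 cells (Homo sapiens) for cytotoxicity, read by CCK-8 assay, with a stated time of 72 h; on this read-out higher numbers stand for weaker inhibition and lower numbers for stronger inhibition:
compound 1, `COc1ccccc1/C=c1/[nH]c(=O)/c(=C\c2ccccc2OC)n(C)c1=O`, gives 1500 nM;
compound 2, `C=CCn1c(=O)/c(=C\c2cc(Br)ccc2F)[nH]c(=O)/c1=C\c1ccccc1OC`, gives 4700 nM;
compound 3, `COc1ccccc1/C=c1\c(=O)[nH]/c(=C/c2cccc(Cl)c2Cl)c(=O)n1C`, gives 100 nM.

Among these three, compound 2 stands at the highest number in this assay, with compound 1 nearest to it and compound 3 furthest away. Among the compounds with values here, the only step measured between two compounds differing in one place is a 15-fold lower number from compound 1 to compound 3 (1.18 log units; beyond the scatter), which swaps the whole aryl group on one side of the shared core.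

Compound 4, `C=CCn1c(=O)/c(=C\c2ccc(F)c(Br)c2)[nH]c(=O)/c1=C\c1ccccc1OC`, is not yet measured. It differs from compound 2 in one place: 3-bromo-4-fluorophenyl in place of 5-bromo-2-fluorophenyl on a double-bonded chain carbon bound to an aromatic carbon. Here the same two halogens are kept but arranged differently on the ring. The step from compound 1 to compound 3 shows that a change of aryl substitution on this double-bonded chain carbon can shift the number strongly, but it concerns different groups and gives no direction for a rearrangement of bromine and fluorine. Compound 4 is therefore expected to land near compound 2, a step of a 1.3-fold lower number from compound 2 to compound 4 (0.13 log units; within the scatter), with the estimate for compound 4 being 3500 nM and a range from 1000 nM to 12000 nM.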

Compound 4, half-maximal inhibitory concentration: "not active" (no number reported)
No number was reported for compound 4; there is nothing to compare the estimate with.
By their numbers in this assay, from the lowest: compound 3; then compound 1; then compound 2.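

In this assay, within the data shown here, compound 4 is reported as "not active" with no number, so no step from compound 2 to compound 4 can be read. No evidence at hand bears on this result. The compounds shown leave open how rearranging bromine and fluorine on this aryl group affects the number.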